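The compounds below may be only part of what the source reports. "The series", "measured", "known", "first", "only" and "open" are said of these compounds alone.

In a functional assay on SiHa cells (Homo sapiens) for antiproliferative activity, read by MTT assay, with a stated time of 48 h (on this read-out lower numbers stand for stronger inhibition and higher numbers for weaker inhibition), two compounds built on the shared core have been measured so far. Compound 1 `C/C(=C\CC/C(C)=C/CC[C@@H]1[C@@]2(C)CCC(=O)C(C)(C)[C@H]2CC[C@@]1(C)O)CC/C=C(\C)C(=O)OCc1cn(-c2cccc(C)c2)nn1` gives > 150000 nM, which is a limit and not a number. Compound 2 `C/C(=C\CC/C(C)=C/CC[C@@H]1[C@@]2(C)CCC(=O)C(C)(C)[C@H]2CC[C@@]1(C)O)CC/C=C(\C)C(=O)OCc1cn(-c2cccc(F)c2)nn1` gives > 150000 nM, also a limit. Compound 2 thus stands with compound 1, and the evidence is the limit of > 150000 nM in this assay, at which 2 of the 2 values shown sit.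

Compound 3 `C/C(=C\CC/C(C)=C/CC[C@@H]1[C@@]2(C)CCC(=O)C(C)(C)[C@H]2CC[C@@]1(C)O)CC/C=C(\C)C(=O)OCc1cn(-c2cccc(O)c2)nn1` replaces the fluoro of compound 2 with hydroxy on an aromatic carbon, meta to a large group: hydroxy in place of fluoro on an aromatic carbon. Among the compounds with values here, only one measured step bears on this change, a swap at the same ring place, and it is a step that the two limits leave unreadable from compound 1 to compound 2. It offers no size to carry over, and no direction can be read from it. In this assay, the expectation is therefore that compound 3 stays near that limit, with no step beyond the scatter. The expected step is a step that the limit leaves unreadable from compound 2 to compound 3. For compound 3 the estimated value is 160000 nM, within an expected range of 70000 nM to 300000 nM.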

Compound 3, half-maximal inhibitory concentration: 48000 nM
The estimate for compound 3 lay 3.3-fold (0.52 log units) above the measured number; the measured number lies below the stated range.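

In this assay, this place on the aromatic ring, meta to a large group, now gives a change that can be read: hydroxy in place of fluoro gives an at least 3.1-fold lower number from compound 2 to compound 3 (0.49 log units; beyond the scatter), and hydroxy in place of methyl gives an at least 3.1-fold lower number from compound 1 to compound 3 (0.49 log units; beyond the scatter). The earlier swap of fluoro for methyl at the same place could not be read, because both of those compounds rest on a limit and not on a number: the limit of > 150000 nM in this assay, at which 2 of the 3 values shown sit. Both new steps are therefore minimum sizes, and compound 3 is the only compound shown here with a number.

From the compounds shown here alone, what remains open is whether the hydrogen-bond donor that enters with hydroxy accounts for the step. A methoxy group or an amine at this place would bear on that, and the compounds shown do not settle how much further the number could fall.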